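From trifluoromethoxy to ethoxy at the assay limit

This account rests on a few compounds, and the source may have more. Where it says the series, first, only, none or still open, it means among the compounds named here.

In a functional assay on Caco-2 cells (Homo sapiens) for antiproliferative activity, read by MTT assay, with a stated time of 48 h (a lower number here means a stronger inhibitor, a higher number a weaker inhibitor), compound 1 `C#CC(C)OC(=O)c1ccc(C(CC)(CC)c2ccc(OCCC(O)(CC)CC)c(C)c2)n1CC` gives > 50000 nM and this is a limit of the assay, not a number. Compound 2 `CCn1c(C(=O)Nc2ccc(OC(F)(F)F)cc2)ccc1C(CC)(CC)c1ccc(OCCC(O)(CC)CC)c(C)c1` gives > 50000 nM in this assay as well, again a limit and not a true number. The picture so far is therefore the limit of > 50000 nM in this assay, at which 2 of the 2 values shown sit, with nothing that could rank compound 2 on a scale.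

The next structure, compound 3 `CCOc1ccc(NC(=O)c2ccc(C(CC)(CC)c3ccc(OCCC(O)(CC)CC)c(C)c3)n2CC)cc1`, keeps the shared core and alters one small group: ethyl in place of trifluoromethyl on an oxygen on an aromatic ring which means ethyl in place of trifluoromethyl on an oxygen on an aromatic ring, turning 4-(trifluoromethoxy)phenyl into 4-ethoxyphenyl.

Among the measured compounds shown here, the only measured step that bears on this is a step that the two limits leave unreadable from compound 1 to compound 2 and it offers no size to carry over, even though it swaps a much larger group on the carbonyl carbon. No change beyond the scatter is therefore expected, and no direction can be foreseen. The expected change is a number no higher from compound 2 to compound 3 (the limit leaves the size open) and it should be read as no real shift. For compound 3 the estimate is 50000 nM with an expected range from 25000 nM to 100000 nM and a result that is again only a limit is the likeliest outcome.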

Compound 3, half-maximal inhibitory concentration: > 50000 nM
Compound 3 ended at the assay's limit; the forecaster's own chance of this, stated with the estimate: 75%; the middle value lies on the limit itself.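

In this assay compound 3 also returns only a limit, not a number, so no step among compound 1, compound 2 and compound 3 can be read, and the ethyl for trifluoromethyl swap has no readable size: the limit of > 50000 nM in this assay, at which 3 of the 3 values shown sit.

The compounds shown leave open how these three rank against one another and whether any change to the shared core would give a true number in this assay.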